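The source may hold more compounds than are shown below. What is called first, only, known or untested is meant among the compounds shown, and "the series" means these compounds.

Compound 1 `CC(C)Sc1nnc(-c2c(CNCC3CC3)c3ccccc3n2C)n1-c1ccccc1` gives 5.24 in a physicochemical assay for lipophilicity; a higher number here means a more lipophilic compound, a lower number a more polar compound. Compound 2 `CC(C)Sc1nnc(-c2c(CNCC3CC3)c3cc(F)ccc3n2C)n1-c1ccccc1`, which carries a fluoro in place of hydrogen on an aromatic carbon, gives 5.4 in this assay; the step of a number 0.16 log units higher from compound 1 to compound 2 (within the scatter) lies within the scatter. On the numbers shown, compound 2 and compound 1 sit within the scatter of each other, so neither stands apart. Compound 3 `CC1CCN(Cc2c(-c3nnc(SC(C)C)n3-c3ccccc3)n(C)c3ccc(F)cc23)CC1` has not yet been measured. It differs from compound 2 by 4-methylpiperidin-1-yl in place of (cyclopropylmethyl)amino on a saturated chain carbon bound to an aromatic carbon. For the measured compounds named here, no measured step touches this kind of change: the only known step, between compound 1 and compound 2, concerns the fluoro and is itself within the scatter, so it offers no guide. From the counted difference alone, an upward step beyond the scatter is expected, a number 0.60 log units higher from compound 2 to compound 3 (beyond the scatter). Compound 3 is therefore estimated at 6 in this assay, with a range from 5.5 to 6.5.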

Compound 3, partition coefficient: 6.12
For compound 3 the middle estimate is 0.12 log units below the measured one; low and high end bracket the measured number.
By their numbers in this assay, from the lowest: compounds 1 and 2 (each within the scatter of the next); then compound 3.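

In this assay, for the compounds shown here, replacing (cyclopropylmethyl)amino with 4-methylpiperidin-1-yl gives a number 0.72 log units higher from compound 2 to compound 3 (beyond the scatter) and so provides the first step here that clears the scatter, which the fluoro change did not. The change at this place therefore registers in the read-out, but it alters several things at once: the entering group has 7 heavy atoms against 5, a six-membered ring instead of a three-membered one, and 0 hydrogen-bond donors against 1. Nothing available explains the rise or assigns it to any one of these differences.

On these data alone, it remains open whether the ring, its methyl or the lost donor carries the step, and a plain piperidin-1-yl or a morpholin-4-yl at this place would bear on that. As far as these compounds go, whether the same change gives a similar step without the fluoro also remains open.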